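The source may hold more compounds than are shown below. What is called first, only, known or untested is meant among the compounds shown, and "the series" means these compounds.

Compound 1 `COc1ccc(/C=C/C(=O)c2cccc(-n3cc(C(C)(C)O)nn3)c2)cc1O` gives 17100 nM in a functional assay on RAW264.7 cells (Mus musculus) for inhibition, with a stated time of 4 days; a higher number here means a weaker inhibitor, a lower number a stronger inhibitor. Compound 2 `CCCCCc1ccc(-c2cn(-c3cccc(C(=O)/C=C/c4ccc(OC)c(O)c4)c3)nn2)cc1` gives > 30000 nM in this assay, which is a limit of the assay rather than a number.

Among the measured compounds shown here, compound 2 therefore stands at the edge of what the measurement can report: it is the one of the two values that sits at the limit of > 30000 nM in this assay, at which 1 of the 2 values shown sits. For the measured compounds named here, the only measured step, an at least 1.7-fold higher number from compound 1 to compound 2 (0.24 log units; that floor lies within the scatter), changes a different part of the molecule, and its floor does not tell whether anything real happened.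

Compound 3 `COc1ccc(/C=C/C(=O)c2cccc(-n3cc(-c4ccc(Br)cc4)nn3)c2)cc1O` differs from compound 2 in one place: bromo in place of pentyl on an aromatic carbon. No measured step touches this part of the structure, so the only guidance is the single step already shown, which itself is of uncertain size. The expectation is therefore no step beyond the scatter in this assay, with a real chance that the value is again reported only as a limit. The expected step is a number no higher from compound 2 to compound 3 (the limit leaves the size open). Compound 3 is estimated to give 30000 nM, within a range from 10000 nM to 90000 nM.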

Compound 3, half-maximal inhibitory concentration: 6570 nM
For compound 3 the middle estimate is 4.6-fold (0.66 log units) above the measured one; the whole stated range lies above it.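

In this assay, bromo in place of pentyl, on the six-membered aromatic ring of carbon only, gives an at least 4.5-fold lower number from compound 2 to compound 3 (0.65 log units; beyond the scatter), which shows that what sits at this place on the ring can change the read-out by more than the scatter. That step is only a floor, and its true size stays unknown, as compound 2 is reported only as a limit of the assay: the limit of > 30000 nM in this assay, at which 1 of the 3 values shown sits.

The other new comparison, 4-bromophenyl in place of 1-hydroxy-1-methylethyl, gives a 2.6-fold lower number from compound 1 to compound 3 (0.42 log units; beyond the scatter), so a substituted phenyl ring on the core can go with a lower number than compound 1, something the earlier step, whose floor lay within the scatter, could not show.

With only pentyl and bromo to compare at this place on the ring, the compounds shown cannot tell whether the lower number follows from losing the long chain or from having bromo there. A shorter chain such as methyl, or a chloro group or an amine at the same place, would help to separate these two readings.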